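The source may hold more compounds than are shown below. What is called first, only, known or untested is meant among the compounds shown, and "the series" means these compounds.

Measured so far in a functional assay on NCI-H520 cells (Homo sapiens) for inhibition, read by MTT assay, with a stated time of 48 h, tested at 10 uM; on this read-out lower numbers stand for less inhibition and higher numbers for more inhibition at the one concentration tested (going by the name of the read-out):
compound 1 `COc1cc(Br)ccc1Nc1cc(NC(=O)Nc2c(Cl)cccc2Cl)ncn1`: 29.1%
compound 2 `COc1ccc(F)cc1Nc1cc(NC(=O)Nc2c(Cl)cccc2Cl)ncn1`: 38.1%
compound 3 `CCc1cccc(Nc2cc(NC(=O)Nc3cc(OC)cc(OC)c3)ncn2)c1`: 23%

Compound 3 gives the lowest of the three numbers in this assay. Compound 1 sits nearest to it, within the scatter, while compound 2 sits furthest, beyond the scatter. Compound 4 `COc1cc(NC(=O)Nc2cc(Nc3ccc(F)c(Cl)c3)ncn2)cc(OC)c1` differs from compound 3 by 3-chloro-4-fluorophenyl in place of 3-ethylphenyl on a nitrogen on an aromatic ring. Among the measured compounds shown here, the only measured step at that same place is a number 9 percentage points higher from compound 1 to compound 2 (within the scatter), a different exchange of aryl groups on that nitrogen, and it stayed within the scatter. For the measured compounds named here, compound 3 differs from compounds 1 and 2 elsewhere as well, and no measured step isolates that change. On this footing, compound 4 is expected to shift by about a number 4 percentage points higher from compound 3 to compound 4 (within the scatter), that is, no step beyond the scatter. Compound 4 is therefore estimated at 27% in this assay, within 12% to 42%.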

Compound 4, a percentage reported as inhibition, at one concentration (the size of the read-out at that concentration, not a potency): 25.5%
Estimate against measurement, compound 4: 1.5 percentage points above, within the range that was stated.
By their numbers in this assay, from the lowest: compounds 3, 4, 1 and 2 (each within the scatter of the next, the first and the last beyond it).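

In this assay the exchange of 3-ethylphenyl for 3-chloro-4-fluorophenyl on this nitrogen gives a number 2.5 percentage points higher from compound 3 to compound 4 (within the scatter) and so an ethyl-bearing ring and a dihalogenated ring read alike here. Together with a number 9 percentage points higher from compound 1 to compound 2 (within the scatter) this makes two aryl exchanges at this position, on two different remainders of the molecule, and neither leaves the scatter. Nothing available explains the small size of either step.

As far as these compounds go, whether a morpholine, a longer alkyl chain, or an aryl ring carrying a carboxylic acid on this nitrogen would move the number beyond the scatter stays open. So does the contribution of the other aryl group, which no single step isolates.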